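Sulfur insertion into the acid side chain of compound 2

The source may hold more compounds than are shown below. What is called first, only, known or untested is meant among the compounds shown, and "the series" means these compounds.

Compound 2 `CC(C)(C)C(=O)CN1C(=O)N(CC(=O)Nc2cccc(CC(=O)O)c2)C(=O)N(C2CCCCCC2)c2ccccc21` carries the shared core of compound 1 `Cc1cccc(NC(=O)CN2C(=O)N(CC(=O)C(C)(C)C)c3ccccc3N(C3CCCCCC3)C2=O)c1` with an added carboxy group. In an assay on CHO-K1 cells for displacement of a labelled ligand from Cholecystokinin receptor type A (Homo sapiens) (on this read-out higher numbers stand for weaker inhibition and lower numbers for stronger inhibition), compound 1 gives 447 nM, and compound 2 gives 3890 nM, the higher of the two numbers on record. Among the compounds with values here, the only step measured so far, an 8.7-fold higher number from compound 1 to compound 2 (0.94 log units; beyond the scatter), describes that carboxy addition. Compound 3 `CC(C)(C)C(=O)CN1C(=O)N(CC(=O)Nc2cccc(SCC(=O)O)c2)C(=O)N(C2CCCCCC2)c2ccccc21` differs from compound 2 by (carboxymethyl)sulfanyl in place of carboxymethyl on an aromatic carbon. Within the data shown here, no measured step concerns such a change: the one step available describes a different alteration, and the acid group itself is kept in both compound 2 and compound 3. Among the measured compounds shown here, with no comparable precedent, the expected step in this assay is a 1.1-fold lower number from compound 2 to compound 3 (0.05 log units; within the scatter), a change that stays within the scatter. Compound 3 is therefore estimated at 3500 nM, within a range from 1200 nM to 10000 nM.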

Compound 3, inhibition constant: 282 nM
Compound 3: middle estimate off by 12-fold (1.09 log units), on the high side; the whole stated range lies above it.
By their numbers in this assay, from the lowest: compounds 3 and 1 (each within the scatter of the next); then compound 2.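

In this assay, this aromatic carbon proves sensitive to a small change in the acid side chain: (carboxymethyl)sulfanyl in place of carboxymethyl gives a 14-fold lower number from compound 2 to compound 3 (1.14 log units; beyond the scatter). Set against the methyl group on the same carbon, the sulfur-linked acid chain gives a 1.6-fold lower number from compound 1 to compound 3 (0.20 log units; within the scatter), so a carboxylic acid on this side chain need not come with the higher number seen earlier. Nothing available explains why this exchange has so large an effect.

Still open, on these data alone, is whether the sulfur atom itself or simply the longer chain lies behind the step, a question that a carboxymethoxy chain, with oxygen in place of sulfur, or a carboxyethyl chain would address. Also open, as far as these compounds go, is whether the free acid matters within the sulfur-linked chain, as a methyl ester would show.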